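The compounds below may be only part of what the source reports. "The series", "measured", "known", "first", "only" and "open" are said of these compounds alone.

Values in a functional assay on MDA-MB-231 cells (Homo sapiens) for cytotoxicity, read by MTT assay, with a stated time of 48 h; on this read-out lower numbers stand for stronger inhibition and higher numbers for weaker inhibition:

compound 1 `O=C1C[C@H](OCc2cc(-c3ccccc3)no2)[C@H]2CO[C@@H]1O2`: 21900 nM
compound 2 `O=C1C[C@H](OCc2cc(-c3ccc(Cl)cc3)no2)[C@H]2CO[C@@H]1O2`: 17900 nM

Compound 2 gives the lower of the two numbers, yet a 1.2-fold lower number from compound 1 to compound 2 (0.09 log units; within the scatter) lies within the scatter, so compound 1 and compound 2 are not separated. Compound 3 `O=C1C[C@H](OCc2cc(C3CCCCC3)no2)[C@H]2CO[C@@H]1O2` differs from compound 2 by cyclohexyl in place of 4-chlorophenyl on an aromatic carbon. Among the measured compounds shown here, no measured step bears on this exchange; the only measured step concerns chloro for hydrogen and stayed within the scatter. Hence in this assay no step beyond the scatter is expected, though the range is wide. For compound 3 the expected value is 25000 nM, spanning 8000 nM to 80000 nM. The estimated step is a 1.4-fold higher number from compound 2 to compound 3 (0.15 log units; within the scatter).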

Compound 3, half-maximal inhibitory concentration: 15800 nM
Compound 3: the middle estimate sits 1.6-fold (0.20 log units) above what was measured, within the range that was stated.
By their numbers in this assay, from the lowest: compounds 3, 2 and 1 (each within the scatter of the next).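

Among the compounds shown here, at the aromatic carbon next to the ring nitrogen, the earlier compounds showed only a change on the phenyl ring; here the whole ring is exchanged. In this assay cyclohexyl in place of 4-chlorophenyl gives (a 1.1-fold lower number from compound 2 to compound 3 (0.05 log units; within the scatter)) and cyclohexyl in place of phenyl gives (a 1.4-fold lower number from compound 1 to compound 3 (0.14 log units; within the scatter)), so the non-aromatic ring is not separated from either aromatic ring. No measurement at hand explains this.

All three compounds carry a six-membered carbon ring here. On these data alone, whether an amine, a carboxylic acid or a longer chain at this carbon would give a step beyond the scatter remains open.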